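This account rests on a few compounds, and the source may have more. Where it says the series, first, only, none or still open, it means among the compounds named here.

Working notes on the permeability series.

Of the compounds shown here, three of the shared core have been measured in an ADME assay on Caco-2 cells (Homo sapiens) for permeability, in the apical to basolateral direction; on this read-out lower numbers stand for lower permeability and higher numbers for higher permeability. Compound 1 `Cn1cncc1CN1CC(N(CC2CCN(C(=O)c3ccc(Cl)cc3)CC2)S(=O)(=O)c2ccccn2)Cc2cc(C#N)ccc21` gives 0.5 10^-6 cm/s. Compound 2 `Cn1cncc1CN1CC(N(CC2CCN(C(=O)CNC(=O)OC(C)(C)C)CC2)S(=O)(=O)c2ccccn2)Cc2cc(C#N)ccc21` gives 0.5 10^-6 cm/s, and compound 3 `CCC(=O)N1CCC(CN(C2Cc3cc(C#N)ccc3N(Cc3cncn3C)C2)S(=O)(=O)c2ccccn2)CC1` gives 0.5 10^-6 cm/s. The three differ only in the group on the carbonyl carbon of the piperidine amide, and the steps there are flat: no change at the digits printed from compound 1 to compound 2 (within the scatter), no change at the digits printed from compound 1 to compound 3 (within the scatter) and no change at the digits printed from compound 2 to compound 3 (within the scatter). Compound 3 thus stands level with compounds 1 and 2, with no separation at the digits shown.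

Compound 4 `Cc1noc(C)c1CN(C1Cc2cc(C#N)ccc2N(Cc2cncn2C)C1)S(=O)(=O)c1ccccn1` is the next compound. Its change from compound 3 is 3,5-dimethyl-1,2-oxazol-4-yl in place of 1-propanoylpiperidin-4-yl on a saturated chain carbon bound to a sulfonamide nitrogen. Within the data shown here, no measured step touches this position; the three flat steps only show that the amide substituent did not move this assay. Nothing measured points in a direction for the step from compound 3 to compound 4, so a value near the common level is expected, with a wide range. The expected step of a 1.4-fold higher number from compound 3 to compound 4 (0.15 log units; within the scatter) is within the scatter. For compound 4 the estimate in this assay is 0.7 10^-6 cm/s, from 0.3 10^-6 cm/s to 2.5 10^-6 cm/s.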

Compound 4, apparent permeability: 8 10^-6 cm/s
The estimate for compound 4 lay 11-fold (1.06 log units) below the measured number; the measured number lies above the stated range.
By their numbers in this assay, from the lowest: compounds 1, 2 and 3 (each within the scatter of the next); then compound 4.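

Among these compounds, the amide substituent left this assay flat, but the group on the saturated chain carbon bound to a sulfonamide nitrogen does not: 3,5-dimethyl-1,2-oxazol-4-yl in place of 1-propanoylpiperidin-4-yl gives a 16-fold higher number from compound 3 to compound 4 (1.20 log units; beyond the scatter), a large step at a place no earlier compound varied. This single change alters several things together, going from a six-membered non-aromatic ring to a five-membered aromatic ring and from 10 heavy atoms to 7, and also removing the double bond outside aromatic rings, so the step cannot be assigned to any one of them. Nothing available explains the size of this step.

From the compounds shown here alone, it remains open whether the step belongs to the aromatic ring or to the loss of the acylated piperidine. A plain phenyl, an unsubstituted 1,2-oxazol-4-yl or a free piperidine amine at this place would help separate these readings.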